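The source may hold more compounds than are shown below. What is called first, only, known or untested is meant among the compounds shown, and "the series" means these compounds.

Working notes on the series. All compounds share one core and differ only in the group on an aromatic nitrogen of the fused ring system. In an assay on HEK-293T cells for antagonist activity at vitamin D3 receptor (Homo sapiens), read by a luciferase reporter, with a stated time of 24 h (on this read-out lower numbers stand for stronger inhibition and higher numbers for weaker inhibition), compound 1 `CCC(CC)n1c(-c2ccc(OCc3c(-c4c(Cl)cccc4Cl)noc3C(C)C)cc2)nc2ccc(C(=O)O)cc21` gives 5690 nM. Compound 2 `CC(C)c1onc(-c2c(Cl)cccc2Cl)c1COc1ccc(-c2nc3ccc(C(=O)O)cc3n2CC2CC2)cc1` gives 2650 nM in this assay, and compound 3 `CC(C)c1onc(-c2c(Cl)cccc2Cl)c1COc1ccc(-c2nc3ccc(C(=O)O)cc3n2C2CCCCCC2)cc1` gives 921 nM in this assay. The three steps all run the same way: a 2.1-fold lower number from compound 1 to compound 2 (0.33 log units; beyond the scatter), a 6.2-fold lower number from compound 1 to compound 3 (0.79 log units; beyond the scatter) and a 2.9-fold lower number from compound 2 to compound 3 (0.46 log units; beyond the scatter). Compound 3 thus stands lowest of the three numbers, with compound 2 nearest and compound 1 furthest, both separations beyond the scatter.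

Compound 4 `CC(C)c1onc(-c2c(Cl)cccc2Cl)c1COc1ccc(-c2nc3ccc(C(=O)O)cc3n2CC2CCCCC2)cc1` is not yet measured. Relative to compound 3 the change is cyclohexylmethyl in place of cycloheptyl on an aromatic nitrogen; the two compounds hold the same atoms joined differently. Within the data shown here, two measured steps bear on the question: pentan-3-yl to cycloheptyl, a 6.2-fold lower number from compound 1 to compound 3 (0.79 log units; beyond the scatter), and cyclopropylmethyl to cycloheptyl, a 2.9-fold lower number from compound 2 to compound 3 (0.46 log units; beyond the scatter). The cyclohexylmethyl group of compound 4 keeps a saturated ring, as in compound 3, but carries the one-carbon link seen in compound 2, so a small step toward a higher number is expected, a 1.5-fold higher number from compound 3 to compound 4 (0.18 log units; within the scatter), without confidence that it clears the scatter. Compound 4 is therefore estimated at 1400 nM in this assay, with a range from 550 nM to 3500 nM.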

Compound 4, half-maximal inhibitory concentration: 346 nM
Estimate against measurement, compound 4: 4.0-fold (0.61 log units) above; the whole stated range lies above it.
By their numbers in this assay, from the lowest: compound 4; then compound 3; then compound 2; then compound 1.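

Moving the same atoms from cycloheptyl to cyclohexylmethyl on the aromatic nitrogen gives a 2.7-fold lower number from compound 3 to compound 4 (0.43 log units; beyond the scatter) in this assay, so at this position the number depends on how the group is joined, not only on which atoms it holds. Among these compounds, with the one-carbon link kept, cyclohexyl in place of cyclopropyl gives a 7.7-fold lower number from compound 2 to compound 4 (0.88 log units; beyond the scatter), so the link does not by itself bring a higher number; the earlier gap between compound 2 and compound 3 had left that open, and cyclohexylmethyl now reaches a 16-fold lower number from compound 1 to compound 4 (1.22 log units; beyond the scatter), the only step printed as large. No measurement among these compounds accounts for either shift.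

The compounds shown leave open whether the number keeps falling with other rings on the same one-carbon link, such as cyclopentylmethyl or cycloheptylmethyl, or with a longer chain such as 2-cyclohexylethyl. They also leave open how a ring holding an amine, such as piperidin-4-ylmethyl, or cyclohexyl joined directly to the aromatic nitrogen, would read in this assay.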